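The compounds below may be only part of what the source reports. "The series", "measured", "known", "first", "only" and "open" are said of these compounds alone.

Among the measured compounds shown here, compound 3 `O=c1ccn(CCCCCOc2ccc(Br)cc2)c(=O)[nH]1` is the one compound of the three that gives a number rather than a limit in an ADME assay on HEL cells (Homo sapiens) for cytotoxicity, read by microscopy; a higher number here means that more compound is tolerated, a lower number that less compound is tolerated: in this assay compound 3 gives 100000 nM. Compound 1 `Cc1ccccc1OCCCCCn1ccc(=O)[nH]c1=O` reaches only a limit in this assay, > 100000 nM. Compound 2 `CCCOC(=O)c1ccc(OCCCCCn2ccc(=O)[nH]c2=O)cc1` likewise reaches only a limit in this assay, >= 100000 nM. Because of the limit of > 100000 nM in this assay, at which 1 of the 3 values shown sits, the step of a number no higher from compound 1 to compound 3 (the limit leaves the size open) cannot be sized, and because of the limit of >= 100000 nM in this assay, at which 1 of the 3 values shown sits, the same holds for a number no higher from compound 2 to compound 3 (the limit leaves the size open); neither step shows any movement that can be read as larger than scatter.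

Compound 4 `Cc1ccc(OCCCCCn2ccc(=O)[nH]c2=O)cc1` differs from compound 3 as methyl in place of bromo on an aromatic carbon. The step from compound 1 to compound 3 already exchanged a methyl-bearing phenyl for the 4-bromophenyl without a readable change in this assay, and the step from compound 2 to compound 3 likewise left the number where it was. He therefore expects no step beyond the scatter for compound 4, an expected change of no change at the digits printed from compound 3 to compound 4 (within the scatter), with a fair chance that the assay again reports only a limit. His estimate for compound 4 in this assay is 100000 nM, expected to lie between 50000 nM and 200000 nM.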

Compound 4, minimum cytotoxic concentration: 100000 nM
For compound 4 middle estimate and measured number coincide at the digits printed; low and high end bracket the measured number.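

In this assay, among the compounds shown here, the step is no change at the digits printed from compound 3 to compound 4 (within the scatter) for methyl in place of bromo on an aromatic carbon, para to a large group, the first step here with a number at both ends. The earlier steps shown here could show only that no movement was readable, whereas this one shows directly that, for this pair, exchanging bromo for methyl at this place leaves the tolerated concentration within the scatter. On these data alone, the other two new steps (a number no higher from compound 2 to compound 4 (the limit leaves the size open) and a number no higher from compound 1 to compound 4 (the limit leaves the size open)) cannot be read, and their size stays open.

The compounds shown leave open whether an amine or a carboxylic acid at this same place, or a longer chain joining the aromatic ring to the shared core, would shift the number in this assay beyond the scatter. How far compound 1 really stands from the compounds with a number also stays open, as its value is only a limit: the limit of > 100000 nM in this assay, at which 1 of the 4 values shown sits.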